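Sulfonamide in place of cinnamamide on the shared core

The compounds below may be only part of what the source reports. "The series", "measured", "known", "first", "only" and "open" are said of these compounds alone.

Among the measured compounds shown here, compound 1 `CCCN(CC[C@H]1CC[C@H](NC(=O)/C=C/c2ccccc2Cl)CC1)[C@H]1CCc2nc(N)sc2C1` gives 1.2 nM in an assay on brain for displacement of a labelled ligand from D(3) dopamine receptor (Rattus norvegicus) (on this read-out higher numbers stand for weaker inhibition and lower numbers for stronger inhibition), the lowest of the two numbers measured so far; its nearest neighbour is compound 2 `CCCN(CC[C@H]1CC[C@H](NC(=O)/C=C/c2ccccc2OC)CC1)[C@H]1CCc2nc(N)sc2C1`, which gives 8.1 nM. For the measured compounds named here, the one measured step, a 6.8-fold higher number from compound 1 to compound 2 (0.83 log units; beyond the scatter), concerns a substituent on the aromatic ring and does not bear on the change now considered. Compound 3 `CCCN(CC[C@H]1CC[C@H](NS(=O)(=O)c2ccccc2Cl)CC1)[C@H]1CCc2nc(N)sc2C1` differs from compound 1 by (2-chlorophenyl)sulfonyl in place of (2-(2-chlorophenyl)ethenyl)carbonyl on an amine nitrogen. Nothing measured covers a change of this kind, so only a cautious expectation is possible: compound 3 is expected to give a higher number, estimated at 20 nM with a range of 4 nM to 150 nM. This expectation amounts to a 17-fold higher number from compound 1 to compound 3 (1.22 log units; beyond the scatter).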

Compound 3, inhibition constant: 0.68 nM
Compound 3: middle estimate off by 29-fold (1.47 log units), on the high side; measured number outside the range, below it.
By their numbers in this assay, from the lowest: compounds 3 and 1 (each within the scatter of the next); then compound 2.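

On the amine nitrogen of the shared core, (2-chlorophenyl)sulfonyl takes the place of (2-(2-chlorophenyl)ethenyl)carbonyl with a 1.8-fold lower number from compound 1 to compound 3 (0.25 log units; within the scatter) and no change beyond the scatter. With the chlorophenyl ring kept, neither the carbonyl nor the ethenyl link is therefore needed for a low number at this position. Nothing available explains why the two groups read alike.

Still open, as far as these compounds go, is whether methoxy in place of chloro shifts the number on the sulfonyl compound as it does on the cinnamamide. A methylsulfonyl group or a urea on the same nitrogen also remains untested in the compounds shown.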